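Omega-chain branching in an EP2 agonist series

This account rests on a few compounds, and the source may have more. Where it says the series, first, only, none or still open, it means among the compounds named here.

Measured so far:
compound 1 `CCCCC(C)(C)[C@H](O)/C=C/[C@H]1CCC(=O)N1CCSc1nc(C(=O)O)cs1` — 0.91 nM
compound 2 `CC#CCC1([C@H](O)/C=C/[C@H]2COC(=O)N2CCSc2nc(C(=O)O)cs2)CCC1` — 21 nM

For the measured compounds named here, in an assay on isolated protein for agonist activity at prostaglandin E2 receptor EP2 subtype (Homo sapiens) (a lower number here means that less compound is needed, a higher number that more compound is needed for the effect), compound 1 gives the lowest number of the two; compound 2 sits well beyond the scatter above it, but the two differ in several places, so no single step is read from them. Compound 3 `CCCC[C@H](C)C[C@H](O)/C=C/[C@H]1CCC(=O)N1CCSc1nc(C(=O)O)cs1` differs from compound 1 only by 2-methylhexyl in place of 1,1-dimethylpentyl on a saturated chain carbon bound to a double-bonded chain carbon and an oxygen on a saturated carbon. A moderate loss is expected, the estimated step from compound 1 to compound 3 being a 3.8-fold higher number from compound 1 to compound 3 (0.59 log units; beyond the scatter), beyond the scatter but small. Compound 3 is therefore estimated at 3.5 nM, with a range of 0.9 nM to 14 nM.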

Compound 3, half-maximal effective concentration: 0.39 nM
Estimate against measurement, compound 3: 9.0-fold (0.95 log units) above; measured number outside the range, below it.
By their numbers in this assay, from the lowest: compound 3; then compound 1; then compound 2.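

Going from 1-hydroxy-2,2-dimethylhexyl to 1-hydroxy-3-methylheptyl gives a 2.3-fold lower number from compound 1 to compound 3 (0.37 log units; beyond the scatter) in this assay. The two chains hold the same atoms, joined differently, so this step reads a change in chain branching alone, and the 1,1-dimethylpentyl arrangement of compound 1 is not required for a low number. Nothing measured here gives a reason for the step.

Open, going by these compounds, are the opposite configuration at the defined stereocentre of 2-methylhexyl and a longer chain or terminal phenyl at this place. On these data alone, whether the step carries over to the core of compound 2 also remains open.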